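The source may report more compounds than this note shows. Statements on the series, on what has been measured and on what is new or still open speak of the compounds shown alone.

Of the compounds shown here, two share one core and have been measured in an ADME assay on Vero cells (Chlorocebus sabaeus) for cytotoxicity, read by neutral red uptake, tested at 787 ug/mL; on this read-out lower numbers stand for a stronger effect and higher numbers for a weaker effect at the one concentration tested. Compound 1 `COc1ccc(C2SCC(=O)N2CCN2CCCCC2)cc1` gives 33% in this assay. Compound 2 `COc1ccccc1C1SCC(=O)N1CCN1CCCCC1` gives 30% in this assay, and although this is the lower of the two numbers, the gap to compound 1 lies within the usual scatter of such measurements, so the two compounds cannot be told apart on these data.

The next compound is compound 3 `O=C1CSC(c2ccccc2[N+](=O)[O-])N1CCN1CCCCC1`, which has not yet been measured in this assay. It differs from compound 2 in a single place: nitro in place of methoxy on an aromatic carbon. From the compounds shown here alone, no comparison between two measured compounds involving this change exists, so the size of its effect in this assay is unknown.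

Among the measured compounds shown here, with only two measured compounds, both giving similar numbers, the most reasonable expectation is that compound 3 stays close to them. The step from compound 2 to compound 3 is expected to be a number 2 percentage points higher from compound 2 to compound 3 (within the scatter), that is, no change beyond the scatter. Compound 3 is therefore estimated to give 32% in this assay, with a range from 15% to 55%.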

Compound 3, a percentage reported as activity, at one concentration (the size of the read-out at that concentration, not a potency): 100%
The estimate for compound 3 lay 68 percentage points below the measured number, outside the stated range (above it).
By their numbers in this assay, from the lowest: compounds 2 and 1 (each within the scatter of the next); then compound 3.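

In this assay, replacing methoxy with nitro on an aromatic carbon, ortho to a large group, gives a number 70 percentage points higher from compound 2 to compound 3 (beyond the scatter), so on this read-out the effect at the tested concentration is much weaker. The earlier compounds shown here both carried methoxy and gave numbers within the scatter of each other, so they could not show that this position responds to the group placed on it; this single swap shows that it can respond strongly. Nothing among the available data explains why the swap has so large an effect, so the result stands as an observation about these two compounds only.

The compounds shown leave open whether the jump belongs to nitro itself or would follow from other replacements of methoxy at this position, such as an amine, a carboxylic acid or a plain chlorine atom. They also leave open whether nitro would have the same effect elsewhere on the aromatic ring, or on a different part of the shared core, since a single step cannot separate these possibilities.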